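A few compounds are considered here, and "the series" means these few. Any claim that something is new, unique, unknown or untested is made for them only; others in the source may bear on it.

Compound 2, `COc1ccc2c(OCC[C@@H]3NC(=O)N(C)CCCC/C=C\[C@@H]4C[C@@]4(C(=O)NS(=O)(=O)C4(C)CC4)NC3=O)cc(-c3nc(C(C)C)cs3)nc2c1Br`, carries a bromo group on its core and gives the lowest of the two numbers measured in an ADME assay (liver) for metabolic stability, with Liver microsome (Rattus norvegicus) as the target, using microsomes, with a stated time of 2 h (on this read-out lower numbers stand for slow clearance and higher numbers for fast clearance), namely 16.5 mL.min-1.g-1. Its chloro counterpart compound 1, `COc1ccc2c(OCC[C@@H]3NC(=O)N(C)CCCC/C=C\[C@@H]4C[C@@]4(C(=O)NS(=O)(=O)C4(C)CC4)NC3=O)cc(-c3nc(C(C)C)cs3)nc2c1Cl`, gives 20.7 mL.min-1.g-1 in this assay, and the step of a 1.3-fold lower number from compound 1 to compound 2 (0.10 log units; within the scatter) stays within the usual scatter. Compound 3, `COc1ccc2c(OCC[C@@H]3NC(=O)N(C)CCCC/C=C\[C@@H]4C[C@@]4(C(=O)NS(=O)(=O)C4(C)CC4)NC3=O)cc(-c3nc(C(C)C)cs3)nc2c1C`, differs from compound 2 by methyl in place of bromo on an aromatic carbon. Within the data shown here, only the step from compound 1 to compound 2 bears on this change, and it was small, so compound 3 is expected to move by a 1.3-fold higher number from compound 2 to compound 3 (0.12 log units; within the scatter), toward slightly faster clearance. Compound 3 is therefore estimated at 22 mL.min-1.g-1, in a range from 11 mL.min-1.g-1 to 45 mL.min-1.g-1.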

Compound 3, intrinsic clearance in microsomes: 9.3 mL.min-1.g-1
Compound 3: the middle estimate sits 2.4-fold (0.37 log units) above what was measured; measured number below the stated range.
By their numbers in this assay, from the lowest: compounds 3, 2 and 1 (each within the scatter of the next, the first and the last beyond it).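

Among these compounds, at this position, on an aromatic carbon ortho to a methoxy group, methyl is the first replacement to give a step beyond the scatter in this assay (a 2.2-fold lower number from compound 1 to compound 3 (0.35 log units; beyond the scatter)). Against bromo, the same group stays within it (a 1.8-fold lower number from compound 2 to compound 3 (0.25 log units; within the scatter)), so methyl separates from chloro but not from bromo. No measurement shown accounts for this difference. Going by these compounds, whether a fluoro group, an ethyl group or a nitrile at this position would give a lower number than methyl remains open.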